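Replacing the Methoxyphenyl Group with a Sulfonamide

This account rests on a few compounds, and the source may have more. Where it says the series, first, only, none or still open, it means among the compounds named here.

In a functional assay on A549 cells (Homo sapiens) for antiproliferative activity, read by MTT assay, with a stated time of 72 h (a higher number here means a weaker inhibitor, a lower number a stronger inhibitor), compound 1 `CCCCc1cn(C[C@H](O)[C@H]2OC(=O)C(OCc3ccccc3)=C2OCc2ccccc2)nn1` gives 28600 nM and compound 2 `CCCCCc1ccc(-c2cn(C[C@H](O)[C@H]3OC(=O)C(OCc4ccccc4)=C3OCc3ccccc3)nn2)cc1` gives 6220 nM. For compound 3 `COc1ccccc1-c1cn(C[C@H](O)[C@H]2OC(=O)C(OCc3ccccc3)=C2OCc2ccccc2)nn1` this assay reports only a limit, > 100000 nM, which is the limit of > 100000 nM in this assay, at which 1 of the 3 values shown sits. Compound 3 thus stands at the weak end of the three: an at least 16-fold higher number from compound 2 to compound 3 (1.20 log units; beyond the scatter) and an at least 3.4-fold higher number from compound 1 to compound 3 (0.54 log units; beyond the scatter). Compound 4 `O=C1O[C@H]([C@@H](O)Cn2cc(CNS(=O)(=O)c3ccc(F)cc3)nn2)C(OCc2ccccc2)=C1OCc1ccccc1` differs from compound 3 by (((4-fluorophenyl)sulfonyl)amino)methyl in place of 2-methoxyphenyl on an aromatic carbon. Both measured steps that touch this aromatic carbon raised the number when 2-methoxyphenyl entered, so removing that group is expected to bring a downward step an at least 2.5-fold lower number from compound 3 to compound 4 (0.39 log units; beyond the scatter), although the entering group resembles neither butyl nor 4-pentylphenyl and the size of the step is uncertain. Compound 4 is therefore estimated at 40000 nM, in a range from 10000 nM to 150000 nM.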

Compound 4, half-maximal inhibitory concentration: 22500 nM
Beside the measured number, compound 4's estimate is 1.8-fold (0.25 log units) above it; the measured number falls inside the stated range.
By their numbers in this assay, from the lowest: compound 2; then compounds 4 and 1 (each within the scatter of the next). At a limit, above all of these: compound 3.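

Compound 3 stands only at a limit: the limit of > 100000 nM in this assay, at which 1 of the 4 values shown sits. Against it, (((4-fluorophenyl)sulfonyl)amino)methyl, a group with a hydrogen-bond donor, gives an at least 4.4-fold lower number from compound 3 to compound 4 (0.64 log units; beyond the scatter), so this aromatic carbon tolerates a non-aryl linked sulfonyl group better than 2-methoxyphenyl. The new group still offers no clear change from butyl, with a 1.3-fold lower number from compound 1 to compound 4 (0.10 log units; within the scatter), and it falls short of 4-pentylphenyl, with a 3.6-fold higher number from compound 2 to compound 4 (0.56 log units; beyond the scatter).

From the compounds shown here alone, whether the 4-fluorophenyl part or the amino hydrogen of the entering group matters stays open. So does how an amine or a carboxylic acid on this aromatic carbon would fare.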